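Sulfonyl homologue replacing the amide on the fluorinated ring

The compounds below may be only part of what the source reports. "The series", "measured", "known", "first", "only" and "open" are said of these compounds alone.

Compound 2 `CC(O[C@H]1CC[C@]2(CC1)COC(C)(C)C2)c1nc(-c2ccc(C(=O)N(C)C)c(F)c2)no1` gives 2460 nM in a functional assay on HEK293 cells for agonist activity at Glucose-dependent insulinotropic receptor (Homo sapiens), read by cAMP accumulation, with a stated time of 30 min (a higher number here means that more compound is needed for the effect, a lower number that less compound is needed), and so stands at the highest number of the two measured here; its nearest neighbour is compound 1 `CC(O[C@H]1CC[C@]2(CC1)COC(C)(C)C2)c1nc(-c2ccc(S(C)(=O)=O)c(F)c2)no1`, which in this assay gives 89 nM. Among the compounds with values here, the only measured step in the set, a 28-fold higher number from compound 1 to compound 2 (1.44 log units; beyond the scatter), is large and beyond the scatter.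

Compound 3 `CC(O[C@H]1CC[C@]2(CC1)COC(C)(C)C2)c1nc(-c2ccc(CS(C)(=O)=O)c(F)c2)no1` carries the change ((methylsulfonyl)methyl in place of dimethylcarbamoyl on an aromatic carbon). Within the data shown here, this brings back a sulfonyl-containing group where compound 1 also has one, but with one more carbon in the chain, so no measured step covers the change exactly. Among the measured compounds shown here, the step from compound 1 to compound 2 bears on it in reverse: a sulfonyl group in place of the amide was the one change that moved this assay strongly, and its direction argues that compound 3 should return toward compound 1 rather than sit with compound 2. From the compounds shown here alone, the extra methylene is untested, so part of that return may not be recovered.

The expected step of an 8.2-fold lower number from compound 2 to compound 3 (0.91 log units; beyond the scatter) is therefore a sizeable drop. Compound 3 is estimated at 300 nM in this assay, with a range of 80 nM to 1200 nM.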

Compound 3, half-maximal effective concentration: 44 nM
Beside the measured number, compound 3's estimate is 6.8-fold (0.83 log units) above it, and the stated range ends above it.
By their numbers in this assay, from the lowest: compound 3; then compound 1; then compound 2.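

At this position, on an aromatic carbon ortho to a fluoro group, the (methylsulfonyl)methyl group does more than recover what the dimethylcarbamoyl group lost in this assay: the result is a 56-fold lower number from compound 2 to compound 3 (1.75 log units; beyond the scatter), a large step. It also passes the directly attached methylsulfonyl group, with a 2.0-fold lower number from compound 1 to compound 3 (0.31 log units; beyond the scatter), a modest step that shows the sulfonyl group need not sit directly on the aromatic ring and that the extra carbon costs nothing in this assay. Nothing available accounts for either step.

Still open, from the compounds shown here alone, is whether the low numbers follow the sulfonyl group or the added carbon: a (dimethylcarbamoyl)methyl group would carry the same extra carbon on the amide side and would separate the two, while a 2-(methylsulfonyl)ethyl group would show whether a longer chain is also accepted. Also open, going by these compounds, is whether a sulfonamide or a carboxylic acid at this position would behave like the sulfonyl groups or like the dimethylcarbamoyl group, and whether the order of these groups holds without the fluoro group.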